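Trihalogenated aryl group on a corticotropin-releasing factor receptor ligand

The source may report more compounds than this note shows. Statements on the series, on what has been measured and on what is new or still open speak of the compounds shown alone.

Measured compounds:
compound 1, `CCCN(CC1CC1)C(=O)c1sc(Nc2c(Cl)cc(Cl)cc2Cl)nc1C`: 360 nM
compound 2, `CCCN(CC1CC1)C(=O)c1sc(Nc2c(Cl)cc(Cl)cc2Cl)nc1C(F)(F)F`: 31000 nM
compound 3, `CCCN(Cc1sc(Nc2c(C)cc(C)cc2Br)nc1C(F)(F)F)CC1CC1`: 21 nM

In an assay for displacement of a labelled ligand from corticotropin-releasing factor receptor 1 (Homo sapiens) (a lower number here means a stronger inhibitor, a higher number a weaker inhibitor), compound 3 gives the lowest number of the three; its steps to compound 1 and to compound 2 are both described as beyond the scatter, so it is the strongest inhibitor among them. Compound 4, `CCCN(Cc1sc(Nc2c(Br)cc(Br)cc2Br)nc1C(F)(F)F)CC1CC1`, differs from compound 3 in one place: 2,4,6-tribromophenyl in place of 2-bromo-4,6-dimethylphenyl on a nitrogen on an aromatic ring. For the measured compounds named here, the only single-point step in the set, an 86-fold higher number from compound 1 to compound 2 (1.94 log units; beyond the scatter), concerns a trifluoromethyl in place of a methyl on an aromatic carbon of the shared core, not the aryl group on the nitrogen, so it does not bear directly on this change. Going by the values given here, compound 3 and compound 2 differ in two places at once, so their values show only that the combination of changes leaves compound 3 much stronger. Among the compounds with values here, no measured step speaks to exchanging methyl for bromine on the aryl ring, so the expectation rests on the change itself: a step of a 1.9-fold higher number from compound 3 to compound 4 (0.28 log units; within the scatter) in this assay, within the scatter or a small weakening. Compound 4 is therefore estimated at 40 nM, with a range from 10 nM to 160 nM.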

Compound 4, inhibition constant: 7.8 nM
The estimate for compound 4 lay 5.1-fold (0.71 log units) above the measured number; the whole stated range lies above it.
By their numbers in this assay, from the lowest: compound 4; then compound 3; then compound 1; then compound 2.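

In this assay, 2,4,6-tribromophenyl in place of 2-bromo-4,6-dimethylphenyl gives a 2.7-fold lower number from compound 3 to compound 4 (0.43 log units; beyond the scatter), a modest step but one beyond the scatter. For the compounds shown here, none of the earlier steps touched this aryl group, so this is the only direct reading of it: on this nitrogen, bromine can take the place of the methyl groups without loss, and the number even falls. The two aryl groups match in their counts of heavy atoms, hydrogen-bond donors and acceptors, and no measurement at hand accounts for the gain.

Going by these compounds, whether the gain needs every bromine stays open, as does how a methoxy or a nitrile in those places on the aryl ring would behave. Also open, on these data alone, is whether this exchange would give a similar step on the core of compound 1.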